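The source may report more compounds than this note shows. Statements on the series, on what has been measured and on what is new or still open speak of the compounds shown alone.

Compound 1 `NCc1ccccc1NC(=O)c1cccc2ccccc12` and compound 2 `NCc1ccccc1NC(=O)c1cc2cc([N+](=O)[O-])ccc2o1` share an aminomethyl-bearing anilide core, but the difference between the two cores is not broken down here. In a physicochemical assay for solubility (a lower number here means a less soluble compound, a higher number a more soluble compound), compound 1 gives 25 ug/mL, while compound 2 gives 5 ug/mL. Compound 3 `CC(C)(C)OC(=O)NCc1ccccc1NC(=O)c1cc2cc([N+](=O)[O-])ccc2o1` differs from compound 2 by tert-butoxycarbonyl in place of hydrogen on an amine nitrogen; in this assay compound 3 gives 25 ug/mL, a step of a 5.0-fold higher number from compound 2 to compound 3 (0.70 log units; beyond the scatter). Compound 4 `CC(C)(C)OC(=O)NCc1ccccc1NC(=O)c1cccc2ccccc12` carries the same change on compound 1, (tert-butoxycarbonyl in place of hydrogen on an amine nitrogen), at an identical place. Within the data shown here, a step of a 2.0-fold higher number from compound 1 to compound 4 (0.30 log units; within the scatter) is expected because the only precedent, a 5.0-fold higher number from compound 2 to compound 3 (0.70 log units; beyond the scatter), went upward, though compound 1 already starts level with compound 3, so a smaller rise seems more likely. Compound 4 is therefore estimated at 50 ug/mL, expected between 15 ug/mL and 150 ug/mL.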

Compound 4, solubility: 5 ug/mL
Compound 4: middle estimate off by 10-fold (1.00 log units), on the high side; the measured number lies below the stated range.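

In this assay, tert-butoxycarbonyl in place of hydrogen on an amine nitrogen gives a fall on one core (a 5.0-fold lower number from compound 1 to compound 4 (0.70 log units; beyond the scatter)) and a rise on the other (a 5.0-fold higher number from compound 2 to compound 3 (0.70 log units; beyond the scatter)). The same change at the same place therefore moved the number in opposite directions, so a step seen on one of these cores is a poor guide to the other. This does not show why the two cores part ways, and nothing available here bears on the reason.

Going by these compounds, whether another group on that amine nitrogen, such as acetyl or methyl, would also split the two cores stays open. Among these compounds, with only two pairs, how the change behaves on a third core also stays open.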